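Adding a nitro group to compound 3: working notes

A few compounds are considered here, and "the series" means these few. Any claim that something is new, unique, unknown or untested is made for them only; others in the source may bear on it.

Measured in a functional assay on NCI-H460 cells (Homo sapiens) for inhibition, read by MTT assay, with a stated time of 24 h, tested at 0.1 ug/mL; on this read-out lower numbers stand for less inhibition of growth and higher numbers for more inhibition of growth at the one concentration tested:
- compound 1 `O=C(CCCCC1CCSS1)NO`: 3.9%
- compound 2 `O=C(CCCCC(S)CCS)NO`: 5.7%
- compound 3 `O=C(CCCCC1CCSS1)Nc1cccc(C(F)(F)F)c1`: "not active" (no number reported)

Compound 3 has no place on the numerical scale: in this assay compound 3 is reported only as "not active" (no number reported), without a number. Compound 1 and compound 2 do have numbers, and the two readings lie within the usual scatter of each other. All that can be said of compound 3 is that it was not credited with activity at the single concentration tested.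

Compound 4 `O=C(CCCCC1CCSS1)Nc1ccc([N+](=O)[O-])c(C(F)(F)F)c1` has not yet been measured. The change to follow is nitro in place of hydrogen on an aromatic carbon, ortho to a trifluoromethyl group and para to a large group.

For the measured compounds named here, with no measured step, nothing shows what this change does. In this assay no step beyond the scatter is expected, and any shift would be toward more inhibition of growth. This expectation rests on the low readings of compound 1 at 3.9% and compound 2 at 5.7%. A report without a number, as for compound 3, also remains possible.

The estimate for compound 4 is 6%, with an expected range from 0% to 20%.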

Compound 4, percent growth inhibition at one concentration: 18.8%
The estimate for compound 4 lay 12.8 percentage points below the measured number; the range from low to high includes it.
By their numbers in this assay, from the lowest: compounds 1 and 2 (each within the scatter of the next); then compound 4.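

In this assay, for the compounds shown here, compound 3 carries no number, so the change to compound 4 at 18.8% gives no step that can be read. As far as these compounds go, what nitro in place of hydrogen does to inhibition of growth therefore stays open, on this scaffold and elsewhere. No available data bear on the reading of compound 4.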